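This account rests on a few compounds, and the source may have more. Where it says the series, first, only, none or still open, it means among the compounds named here.

Measured compounds:
compound 1, `Cc1cc(S(=O)(=O)Nc2nc3ccccc3c(=O)n2N)c(S)cc1Cl`, gives 19000 nM in a functional assay on NCI-H522 cells (Homo sapiens) for inhibition; a higher number here means a weaker inhibitor of growth, a lower number a stronger inhibitor of growth
compound 2, `Cc1cc(S(=O)(=O)Nc2nc3cc(-c4ccccc4)sc3c(=O)n2Cc2ccccc2)c(S)cc1Cl`, gives > 100000 nM in this assay

For the measured compounds named here, compound 1 is the one measured compound with a number of its own, 19000 nM in this assay. For compound 2 the assay reports only a limit, > 100000 nM, not a number. Compound 2 therefore stands at the limit of > 100000 nM in this assay, at which 1 of the 2 values shown sits. Going by the values given here, with only a limit for compound 2, no step between the two measured compounds is counted, and the two values show only that compound 1 has a number while compound 2 does not.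

Compound 3, `Cc1cc(S(=O)(=O)Nc2nc3cc(-c4ccc(Cl)cc4)sc3c(=O)n2Cc2ccccc2)c(S)cc1Cl`, differs from compound 2 in one place: chloro in place of hydrogen on an aromatic carbon. There is no measured step of this kind among the compounds shown to scale the change. A single added chloro on the phenyl is not expected to move the growth inhibition beyond the scatter from where compound 2 stands. The step from compound 2 to compound 3 is expected to be a number no higher from compound 2 to compound 3 (the limit leaves the size open), that is, none beyond the scatter. Compound 3 is estimated at 100000 nM, with a range from 40000 nM to 300000 nM, and the assay is expected most likely to report again only a limit.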

Compound 3, concentration for 50% growth inhibition: > 100000 nM
Compound 3 ended at the assay's limit; the forecaster's own chance of this, stated with the estimate: 75%; the middle value sits exactly at the limit.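

For the compounds shown here, compound 3, like compound 2, is reported only as a limit in this assay and not as a number, so no step between compound 2 and compound 3 can be read. The compounds shown leave open whether going from phenyl to 4-chlorophenyl changes growth inhibition at all, and how far either compound lies beyond the limit.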